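Permeability notes on the quinazolinone ether series

The source may report more compounds than this note shows. Statements on the series, on what has been measured and on what is new or still open speak of the compounds shown alone.

Measured so far:
compound 1 `O=c1ncn(Cc2c(F)cc(F)cc2F)c2ccc(Oc3ccccc3C(F)(F)F)cc12`: 9.2 10^-6 cm/s
compound 2 `O=C(Nc1ccccc1)c1cccc(Oc2ccc3c(c2)c(=O)ncn3Cc2c(F)cc(F)cc2F)c1C(F)(F)F`: 0.84 10^-6 cm/s

In an ADME assay on Caco-2 cells (Homo sapiens) for permeability, in the apical to basolateral direction (a lower number here means that the compound crosses the layer more slowly, a higher number that the compound crosses the layer faster), compound 1 gives 9.2 10^-6 cm/s and compound 2 gives 0.84 10^-6 cm/s. Among the measured compounds shown here, the one measured step is an 11-fold lower number from compound 1 to compound 2 (1.04 log units; beyond the scatter); compound 2 therefore stands as the lower of the two numbers, with compound 1 the nearest comparison and well beyond the scatter from it.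

Compound 3 `O=C(Nc1cccnc1)c1cccc(Oc2ccc3c(c2)c(=O)ncn3Cc2c(F)cc(F)cc2F)c1C(F)(F)F` differs from compound 2 in one place: pyridin-3-yl in place of phenyl on an amide-type nitrogen. For the measured compounds named here, no measured step bears on this change, since the single step in hand, from compound 1 to compound 2, installs the whole phenylcarbamoyl group rather than altering the ring on its amide-type nitrogen. The expectation therefore rests on compound 2 alone, whose value in this assay is 0.84 10^-6 cm/s, with the change adding one hydrogen-bond acceptor and no donor. A step of a 1.3-fold lower number from compound 2 to compound 3 (0.11 log units; within the scatter) is expected, at most modest and possibly within the scatter. For compound 3 the estimate is 0.65 10^-6 cm/s, within a range from 0.3 10^-6 cm/s to 1.6 10^-6 cm/s.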

Compound 3, apparent permeability: 0.26 10^-6 cm/s
Compound 3: middle estimate off by 2.5-fold (0.40 log units), on the high side; the measured number lies below the stated range.
By their numbers in this assay, from the lowest: compound 3; then compound 2; then compound 1.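

The ring on the amide-type nitrogen is not a neutral place in this assay: pyridin-3-yl in place of phenyl, with 6 heavy atoms on both sides and 1 hydrogen-bond acceptor against 0, gives a 3.2-fold lower number from compound 2 to compound 3 (0.51 log units; beyond the scatter) and so lies beyond the scatter. The earlier step showed only what installing the whole phenylcarbamoyl group on an aromatic carbon does, whereas the ring at the far end of that group now proves to count as well. Taken whole, (pyridin-3-yl)carbamoyl in place of hydrogen gives a 35-fold lower number from compound 1 to compound 3 (1.55 log units; beyond the scatter) and thus goes further than the phenylcarbamoyl group, though each reading rests on a single pair of compounds. No measurement in hand bears on why the number falls with this change.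

Still open, going by these compounds, is how the number responds to other groups on the same nitrogen, such as a methyl group, a cyclohexyl ring or a pyridin-4-yl ring. On these data alone, it is equally open whether the step from phenyl to pyridin-3-yl keeps its size where the trifluoromethyl group on the shared core is replaced by a chlorine atom.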